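The source may hold more compounds than are shown below. What is called first, only, known or untested is meant among the compounds shown, and "the series" means these compounds.

Measured so far:
compound 1, `Nc1ncnc2c1ncn2[C@@H]1O[C@H](CN(CCCc2cccc3ccccc23)CCC[C@H](N)C(=O)O)[C@@H](O)[C@H]1O`, 1100 nM
compound 2, `Nc1ncnc2c1ncn2[C@@H]1O[C@H](CN(CCCc2cccc3ccccc23)CC[C@H](N)C(=O)O)[C@@H](O)[C@H]1O`, 11800 nM

These numbers come from an assay on cells for inhibition of Nicotinamide N-methyltransferase (Homo sapiens), read by fluorescence and coupled enzyme assay, with a stated time of 10 min, in the presence of a further agent that is not named here; on this read-out higher numbers stand for weaker inhibition and lower numbers for stronger inhibition. Among the measured compounds shown here, of the two, compound 2 gives the highest number, and the only step known, an 11-fold higher number from compound 1 to compound 2 (1.03 log units; beyond the scatter), concerns the amino-acid arm alone.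

Compound 3, `Cc1ccc(C#CCN(CC[C@H](N)C(=O)O)C[C@H]2O[C@@H](n3cnc4c(N)ncnc43)[C@H](O)[C@@H]2O)cc1C(N)=O`, keeps the shorter arm of compound 2 and changes the other substituent on the amine: a group of 12 heavy atoms (10 carbon, 1 nitrogen, 1 oxygen; one six-membered aromatic ring of carbon only) in place of a group of 12 heavy atoms (12 carbon; 2 six-membered aromatic rings of carbon only), on a saturated chain carbon bound to an amine nitrogen. For the measured compounds named here, no measured pair shows this kind of exchange, so the one known step, which is large but sits on a different part of the molecule, gives no direct guide to its size or direction in this assay.

Compound 3 is therefore expected to lie broadly near compound 2, with a wide range, the estimated shift being a 3.9-fold lower number from compound 2 to compound 3 (0.59 log units; beyond the scatter). The estimate for compound 3 is 3000 nM, within 300 nM to 30000 nM.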

Compound 3, inhibition constant: 16 nM
Compound 3: the middle estimate sits 190-fold (2.27 log units) above what was measured; measured number outside the range, below it.
By their numbers in this assay, from the lowest: compound 3; then compound 1; then compound 2.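

Replacing 2-(naphthalen-1-yl)ethyl on the saturated chain carbon bound to an amine nitrogen gives a 740-fold lower number from compound 2 to compound 3 (2.87 log units; beyond the scatter), so this substituent, and not only the amino-acid arm, can move the number strongly. Both groups hold 12 heavy atoms, so that count alone does not set the result; the entering group instead has one aromatic ring rather than two, a triple bond, and a hydrogen-bond donor and acceptor. No measurement available here shows which of these differences is responsible.

From the compounds shown here alone, it remains open whether the amide, the methyl or the triple bond carries the change, and a nitrile or a carboxylic acid in place of the amide would help test the first. Also open, going by these compounds, is how the longer amino-acid arm of compound 1 behaves alongside the new group.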